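The compounds below may be only part of what the source reports. "The series", "measured", "known", "first", "only" and "open" are said of these compounds alone.

The two measured compounds:
compound 1 `COc1cc(C2=NN(C(C)=O)C(c3cc(Cl)cc(Cl)c3)O2)cc(OC)c1OC`, which in a functional assay on PC-3 cells (Homo sapiens) for antiproliferative activity, read by MTT assay, tested at 5 uM (a lower number here means a weaker effect, a higher number a stronger effect of the compound at the concentration tested), gives 93.9%
compound 2 `COc1cc(C(=O)N/N=C/c2ccc(Cl)c([N+](=O)[O-])c2)cc(OC)c1OC`, which in this assay gives 42.3%

Compound 1 holds the higher of the two numbers, and its gap to compound 2 lies beyond the scatter. Compound 3 `COc1cc(C2=NN(C(C)=O)C(c3cccc(C(F)(F)F)c3)O2)cc(OC)c1OC` is not yet measured. It differs from compound 1 in one place: 3-(trifluoromethyl)phenyl in place of 3,5-dichlorophenyl on a saturated ring carbon. Among the measured compounds shown here, no pair of measured compounds shows this change, so the expectation rests on compound 1 alone. In this assay a modest drop is expected, a number 11.9 percentage points lower from compound 1 to compound 3 (beyond the scatter), possibly within the scatter. Compound 3 is estimated at 82%, with a range from 55% to 97%.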

Compound 3, a percentage reported as inhibition, at one concentration (the size of the read-out at that concentration, not a potency): 43.6%
Compound 3: the middle estimate sits 38.4 percentage points above what was measured; measured number outside the range, below it.
By their numbers in this assay, from the lowest: compounds 2 and 3 (each within the scatter of the next); then compound 1.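

In this assay the swap to 3-(trifluoromethyl)phenyl from 3,5-dichlorophenyl on the saturated ring carbon gives a number 50.3 percentage points lower from compound 1 to compound 3 (beyond the scatter) as a large step. This position is therefore sensitive to the choice of aryl group, and on the core of compound 1 these two groups are not interchangeable. No measurement shown gives a reason for this step. Among the compounds shown here, with only this one change at the position, it remains open which part of the 3,5-dichlorophenyl group matters. A plain phenyl, a pyridine ring or a phenyl carrying an amine could show how the read-out responds here.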